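From vinyl to 1-bromoethyl on the amide carbonyl

A few compounds are considered here, and "the series" means these few. Any claim that something is new, unique, unknown or untested is made for them only; others in the source may bear on it.

Compound 1 `CCC(=O)N(Cc1ccc(OC)c(O)c1)c1cc(OC)c(OC)c(OC)c1` gives 50 nM in a functional assay on MGC-803 cells (Homo sapiens) for inhibition, read by MTT assay, with a stated time of 48 h; on this read-out lower numbers stand for stronger inhibition and higher numbers for weaker inhibition. Compound 2 `COc1ccc(CN(C(=O)CCCCCl)c2cc(OC)c(OC)c(OC)c2)cc1O` gives 540 nM in this assay. Compound 3 `C=CC(=O)N(Cc1ccc(OC)c(O)c1)c1cc(OC)c(OC)c(OC)c1` gives 62 nM in this assay.

Among these three, compound 3 holds the second highest number, lying within the scatter of compound 1 (a 1.2-fold higher number from compound 1 to compound 3 (0.09 log units; within the scatter)) and well apart from compound 2 (an 8.7-fold lower number from compound 2 to compound 3 (0.94 log units; beyond the scatter)). Compound 4 `COc1ccc(CN(C(=O)C(C)Br)c2cc(OC)c(OC)c(OC)c2)cc1O` differs from compound 3 at the carbonyl carbon: 1-bromoethyl in place of vinyl on a carbonyl carbon. Among the measured compounds shown here, two measured steps bear on this. Exchanging ethyl for vinyl, a 1.2-fold higher number from compound 1 to compound 3 (0.09 log units; within the scatter), stayed within the scatter, whereas adding a halogen-bearing chain, an 11-fold higher number from compound 1 to compound 2 (1.03 log units; beyond the scatter), brought a large rise. Since 1-bromoethyl carries fewer heavy atoms than 4-chlorobutyl, a smaller rise is expected, a 2.1-fold higher number from compound 3 to compound 4 (0.32 log units; beyond the scatter). Compound 4 is therefore expected at 130 nM, with a range of 45 nM to 400 nM.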

Compound 4, half-maximal inhibitory concentration: 120 nM
Estimate against measurement, compound 4: 1.1-fold (0.03 log units) above, within the range that was stated.
By their numbers in this assay, from the lowest: compounds 1, 3 and 4 (each within the scatter of the next, the first and the last beyond it); then compound 2.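

In this assay, 1-bromoethyl on the carbonyl carbon shows that a halogen-bearing group here need not cost as much as 4-chlorobutyl (a 4.5-fold lower number from compound 2 to compound 4 (0.65 log units; beyond the scatter)). Against the ethyl of compound 1, bromo in place of hydrogen still brings a modest rise (a 2.4-fold higher number from compound 1 to compound 4 (0.38 log units; beyond the scatter)). Against vinyl, the step (a 1.9-fold higher number from compound 3 to compound 4 (0.29 log units; within the scatter)) stays within the scatter, so compound 3 and compound 4 cannot be ordered.

No evidence here accounts for these steps. Open, as far as these compounds go, is how 1-chloroethyl or an amine-bearing chain would read at this carbonyl carbon.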